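Adding a Trifluoromethyl to the Benzoyl Arm

The compounds below may be only part of what the source reports. "The series", "measured", "known", "first", "only" and "open" are said of these compounds alone.

Three triazene amides were measured in a functional assay on HeLa cells (Homo sapiens) for cytotoxicity, read by MTT assay, with a stated time of 72 h; a lower number here means a stronger inhibitor, a higher number a weaker inhibitor:

Compound 1, `CC(=O)Oc1ccc(/C=C/C(=O)N(/N=N/c2ccc(Cl)c(C(F)(F)F)c2)c2ccc(Cl)c(C(F)(F)F)c2)cc1OC(C)=O`, gives 43000 nM.
Compound 2, `CC(=O)OCC(=O)N(/N=N/c1ccc([N+](=O)[O-])cc1Br)c1ccc([N+](=O)[O-])cc1Br`, gives 490 nM.
Compound 3, `O=C(c1ccccc1)N(/N=N/c1ccc([N+](=O)[O-])cc1C(F)(F)F)c1ccc([N+](=O)[O-])cc1C(F)(F)F`, gives 600 nM.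

Among these three numbers compound 3 stands second highest. Its nearest neighbour is compound 2, whose value lies within the usual scatter of compound 3, so the two cannot be told apart. Compound 1 stands far away, with a value beyond the scatter, so compound 3 is clearly the stronger of that pair.

Compound 4, `O=C(c1cccc(C(F)(F)F)c1)N(/N=N/c1ccc([N+](=O)[O-])cc1C(F)(F)F)c1ccc([N+](=O)[O-])cc1C(F)(F)F`, differs from compound 3 in a single place: trifluoromethyl in place of hydrogen on an aromatic carbon. The new group sits on an aromatic carbon of a six-membered aromatic ring of carbon only, meta to a large group; in other words, benzoyl becomes (3-(trifluoromethyl)phenyl)carbonyl.

Going by the values given here, no measured pair shows what this change does here. The expectation is a step of a 1.1-fold lower number from compound 3 to compound 4 (0.04 log units; within the scatter), which is small and not beyond the scatter. Compound 4 is therefore estimated at 550 nM, with a range from 150 nM to 2000 nM.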

Compound 4, half-maximal inhibitory concentration: 750 nM
Beside the measured number, compound 4's estimate is 1.4-fold (0.13 log units) below it; the range from low to high includes it.
By their numbers in this assay, from the lowest: compounds 2, 3 and 4 (each within the scatter of the next); then compound 1.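

In this assay, trifluoromethyl in place of hydrogen on the benzoyl ring gives a 1.3-fold higher number from compound 3 to compound 4 (0.10 log units; within the scatter) and this step lies within the scatter, so compound 3 and compound 4 cannot be told apart. Going by these compounds alone, this is the first single-place comparison in the set, and it shows that this aromatic carbon, meta to a large group, can carry trifluoromethyl instead of hydrogen without a readable change in cytotoxicity. Nothing available here explains this result.

On these data alone, it remains open whether a different group on this same carbon, such as an amine or a carboxylic acid, would shift the number beyond the scatter. As far as these compounds go, it is also open whether trifluoromethyl on another carbon of this ring would leave the number just as unchanged.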